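A methyl in place of the formyl on compound 1

The source may report more compounds than this note shows. Statements on the series, on what has been measured and on what is new or still open speak of the compounds shown alone.

Two compounds have numbers in an assay for inhibition of Dihydrofolate reductase (Homo sapiens); on this read-out lower numbers stand for lower potency and higher numbers for higher potency (the scale is a negative logarithm). Compound 1 `Nc1nc(N)c2cc(C=O)ccc2n1` gives 5 and stands lowest of the two; compound 2 `Nc1nc(N)c2cc(Sc3cccc(C(F)(F)F)c3)ccc2n1` gives 7.44, a gap beyond the scatter. Compound 3 `Cc1ccc2nc(N)nc(N)c2c1` differs from compound 1 in one place: methyl in place of formyl on an aromatic carbon. Among the measured compounds shown here, no measured pair shows the effect of a change like this, so the step can only be guessed. Compound 3 is expected to gain a little, a step of a number 0.60 log units higher from compound 1 to compound 3 (beyond the scatter) of modest size, possibly none beyond the scatter. The estimate for compound 3 in this assay is 5.6, between 4.8 and 6.5.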

Compound 3, logarithm of the reciprocal of the active concentration, log(1/C): 5.66
The estimate for compound 3 lay 0.06 log units below the measured number, within the range that was stated.
By their numbers in this assay, from the lowest: compound 1; then compound 3; then compound 2.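

In this assay, methyl in place of formyl on this aromatic carbon gives a number 0.66 log units higher from compound 1 to compound 3 (beyond the scatter), the first single-place step read at this position. The position therefore does not depend on the formyl or its hydrogen-bond acceptor, and a single carbon suffices to give a modest gain. No measurement on hand explains the step.

Going by these compounds, whether a bare hydrogen at this carbon would match the methyl or the formyl remains open. So does how an amine, a carboxylic acid or a longer chain would fare there.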